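The source may hold more compounds than are shown below. What is called first, only, known or untested is meant among the compounds shown, and "the series" means these compounds.

Measured in a functional assay on SW-620 cells (Homo sapiens) for antiproliferative activity, read by MTT assay, with a stated time of 3 days; a lower number here means a stronger inhibitor, a higher number a weaker inhibitor:
Compound 1 `CCCCCC#Cc1cn(C/C=C/CN2C(=O)c3ccccc3C2=O)c(=O)[nH]c1=O`: 58000 nM
Compound 2 `CCCCc1ccc(C#Cc2cn(C/C=C/CN3C(=O)c4ccccc4C3=O)c(=O)[nH]c2=O)cc1`: > 100000 nM

Compound 2 gives > 100000 nM, which is a limit of the assay and not a number. Compound 3 `O=C1c2ccccc2C(=O)N1C/C=C/Cn1cc(C#CCCc2ccccc2)c(=O)[nH]c1=O` carries phenethyl in place of 4-butylphenyl on a triple-bonded carbon. Among the compounds with values here, one measured step bears on this change, an at least 1.7-fold higher number from compound 1 to compound 2 (0.23 log units; that floor lies within the scatter), and it alters the group at the same place. From that step, only a modest move toward a lower number is expected in this assay. The estimated step is an at least 1.4-fold lower number from compound 2 to compound 3 (0.15 log units; that floor lies within the scatter). Compound 3 is expected at 70000 nM, with an estimated range of 25000 nM to 150000 nM.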

Compound 3, half-maximal inhibitory concentration: 11000 nM
Estimate against measurement, compound 3: 6.4-fold (0.80 log units) above; the whole stated range lies above it.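

Phenethyl on the triple-bonded carbon separates clearly from both earlier groups, and the aromatic ring does not by itself weaken the compound. In this assay, replacing 4-butylphenyl with phenethyl gives an at least 9.0-fold lower number from compound 2 to compound 3 (0.95 log units; beyond the scatter). Replacing propyl with phenyl on the saturated chain gives a 5.3-fold lower number from compound 1 to compound 3 (0.72 log units; beyond the scatter), so compound 3 has the lowest number of the three. The first step is only a floor, since the value of compound 2 is a limit of the assay: the limit of > 100000 nM in this assay, at which 1 of the 3 values shown sits.

On these data alone, it remains open how the length of the saturated chain before the ring matters, as with benzyl or 3-phenylpropyl. As far as these compounds go, the effect of an amine or a carboxylic acid on that ring also remains open.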